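Carboxy to ethoxycarbonyl: the step to compound 3

The compounds below may be only part of what the source reports. "The series", "measured", "known", "first", "only" and "open" are said of these compounds alone.

Compound 1 `COc1ccc(C2=C(c3cc(OC)c(OC)c(OC)c3)C(=O)C(O)C2)cc1`: < 1 ug/mL (a limit)
Compound 2 `COc1cc(C2=C(c3ccc(OCC(=O)O)cc3)C(O)CC2=O)cc(OC)c1OC`: > 100 ug/mL (a limit)

Both readings come from an ADME assay on MIA PaCa-2 cells (Homo sapiens) for cytotoxicity, read by MTT assay, with a stated time of 72 h (a lower number here means a stronger inhibitor, a higher number a weaker inhibitor), and neither is a number. Compound 2 gives only a limit, > 100 ug/mL, on the weak side of the two readings. Compound 3 `CCOC(=O)COc1ccc(C2=C(c3cc(OC)c(OC)c(OC)c3)C(=O)CC2O)cc1` differs from compound 2 by ethyl in place of hydrogen on an oxygen next to a carbonyl group, with ethyl in place of hydrogen on an oxygen next to a carbonyl group, so that carboxy becomes ethoxycarbonyl. For the measured compounds named here, no measured step gives the size of this change. Going by the values given here, compound 1 at < 1 ug/mL, a limit, is the only reading on the strong side and the only guide to how far the value may move. The expected step is an at least 12-fold lower number from compound 2 to compound 3 (1.09 log units; beyond the scatter), large and toward a stronger inhibitor. Compound 3 is expected at 8 ug/mL, with an estimated range of 1 ug/mL to 60 ug/mL in this assay.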

Compound 3, half-maximal inhibitory concentration: > 100 ug/mL
Compound 3 ended at the assay's limit; the forecaster's own chance of this, stated with the estimate: 35%; middle value at least 12-fold (1.09 log units) from the limit.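

In this assay compound 3 gives > 100 ug/mL, a limit. Compound 2 gives > 100 ug/mL, also a limit, so no step can be read between these two compounds. As far as these compounds go, whether carboxy and ethoxycarbonyl differ at all in this assay, and by how much, stays open.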